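This account rests on a few compounds, and the source may have more. Where it says the series, first, only, none or still open, it means among the compounds named here.

Measured compounds:
compound 1 `CCCc1ccc(/C=C/C(=O)Nc2ccc3nc(CCC)cc(N)c3c2)cc1` — 4 nM
compound 2 `CCCc1cc(N)c2cc(NC(=O)c3ccc(C(F)(F)F)cc3)ccc2n1` — 10000 nM
compound 3 `Nc1cc(C2CCC2)nc2ccc(NC(=O)/C=C/c3ccc(C(F)(F)F)cc3)cc12` — 2 nM

In an assay on isolated protein for displacement of a labelled ligand from melanin-concentrating hormone receptor 1 (Homo sapiens) (on this read-out lower numbers stand for stronger inhibition and higher numbers for weaker inhibition), compound 1 gives 4 nM, the second highest of the three numbers. Compound 3 gives 2 nM, and the two values lie within the scatter of each other, so no order between them is drawn. Compound 2, which lacks the double-bonded chain between the amide and its aryl ring, gives 10000 nM, far beyond the scatter from both others.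

Compound 4 `CCCc1cc(N)c2cc(NC(=O)/C=C/c3ccc(Cl)c(Cl)c3)ccc2n1` is not yet measured. It differs from compound 1 in one place: 3,4-dichlorophenyl in place of 4-propylphenyl on a double-bonded chain carbon bound to a double-bonded chain carbon. The amide, the double-bonded chain and the shared core are kept.

Among the measured compounds shown here, no measured pair isolates a change on this aryl ring, so the expectation rests on compounds 1 and 3, which carry different aryl substituents and different groups on the core and still give values within the scatter of each other; with two compounds this is no pattern. The step expected a 1.5-fold higher number from compound 1 to compound 4 (0.18 log units; within the scatter) is small, at most a modest loss, and may stay within the scatter. For compound 4 the estimate in this assay is 6 nM, with a range from 2 nM to 25 nM.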

Compound 4, half-maximal inhibitory concentration: 60 nM
Compound 4: the middle estimate sits 10-fold (1.00 log units) below what was measured; measured number above the stated range.
By their numbers in this assay, from the lowest: compounds 3 and 1 (each within the scatter of the next); then compound 4; then compound 2.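

In this assay, the aryl ring on the double-bonded chain proves sensitive to its substituents: 3,4-dichlorophenyl in place of 4-propylphenyl gives a 15-fold higher number from compound 1 to compound 4 (1.18 log units; beyond the scatter), with the amide, the double-bonded chain and the shared core kept. Among the compounds shown here, this is the first pair to isolate a change on this ring, and it shows that such a change alone can move the number beyond the scatter, which the earlier compounds, each differing in more than one place, could not show. Both groups have one six-membered aromatic ring of carbon only, no hydrogen-bond donors or acceptors and no net charge, so those counts do not separate them, and nothing at hand bears on the reason for the step.

A single pair cannot tell whether the step tracks the loss of the propyl chain or the entry of the two chlorines. Going by these compounds, how a 4-chlorophenyl, a 4-butylphenyl or a 4-methoxyphenyl group would read on the same chain carbon with this core remains open.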